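This account rests on a few compounds, and the source may have more. Where it says the series, first, only, none or still open, it means among the compounds named here.

Compound 1, `CCOC(=O)C1=C(Nc2ccccc2)S/C(=C\c2cccc(C(=O)O)c2)C1=O`, in a functional assay on MCF7 cells (Homo sapiens) for inhibition, read by MTT assay, with a stated time of 72 h, tested at 10 uM (a higher number here means more inhibition at the concentration tested (going by the name of the read-out), a lower number less inhibition), gives < 10%, a limit of the assay.
Compound 2, `CCOC(=O)C1=C(Nc2ccccc2)S/C(=C\c2ccc[nH]2)C1=O`, gives 18.3%.
Compound 3, `CCOC(=O)C1=C(Nc2ccc(C(F)(F)F)cc2)S/C(=C\c2ccc[nH]2)C1=O`, gives 19.1%.

Compound 2 stands lowest of the two numbers; its nearest neighbour is compound 3, with a step of a number 0.8 percentage points higher from compound 2 to compound 3 (within the scatter). Compound 1 sits at the limit of < 10% in this assay, at which 1 of the 3 values shown sits, and the step of a number at least 8.3 percentage points higher from compound 1 to compound 2 (that floor lies within the scatter) has a floor that lies within the scatter.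

Compound 4, `CCOC(=O)C1=C(Nc2cccc(C(F)(F)F)c2)S/C(=C\c2ccc[nH]2)C1=O`, differs from compound 2 by trifluoromethyl in place of hydrogen on an aromatic carbon. For the measured compounds named here, the only measured step that bears on this is the one from compound 2 to compound 3, also trifluoromethyl in place of hydrogen on an aromatic carbon, which stayed within the scatter. Compound 4 is therefore expected to show a number 0.7 percentage points higher from compound 2 to compound 4 (within the scatter), no step beyond the scatter. Compound 4 is estimated at 19%, in a range from 8% to 30%.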

Compound 4, a percentage reported as inhibition, at one concentration (the size of the read-out at that concentration, not a potency): 22.9%
Compound 4: middle estimate off by 3.9 percentage points, on the low side; measured number inside the range.
By their numbers in this assay, from the lowest: compounds 2, 3 and 4 (each within the scatter of the next). At a limit, below all of these: compound 1.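

Meta to a large group, trifluoromethyl in place of hydrogen gives a number 4.6 percentage points higher from compound 2 to compound 4 (within the scatter) in this assay. The change has now been read at a second place on the aromatic ring, and here too it stays within the scatter. Nothing on hand bears on why the number falls where it does.

The compounds shown leave open whether an amine or a carboxylic acid at this same place would carry the number beyond the scatter. They also leave open whether trifluoromethyl would behave alike with another group in place of the 1H-pyrrol-2-yl.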